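A few compounds are considered here, and "the series" means these few. Any claim that something is new, unique, unknown or untested is made for them only; others in the source may bear on it.

Measured compounds so far:
compound 1, `CC1(C)CCC(C)(C)c2cc(-c3ccc(/C=C/C(=O)O)cc3)ccc21`: 0.32 nM
compound 2, `CC1(C)CCC(C)(C)c2cc(-c3ccc4cc(C(=O)O)ccc4c3)ccc21`: 0.007 nM

In a functional assay on trachea (Cricetinae), with a stated time of 10 days (on this read-out higher numbers stand for weaker inhibition and lower numbers for stronger inhibition), compound 2 gives 0.007 nM, the lowest of the two numbers recorded. Compound 1 gives 0.32 nM in this assay, a higher number, and the gap between the two lies well beyond the scatter of repeated measurements.

Compound 3, `Cc1c(-c2ccc3c(c2)C(C)(C)CCC3(C)C)ccc2cc(C(=O)O)ccc12`, has not yet been measured. It differs from compound 2 in a single place: methyl in place of hydrogen on an aromatic carbon. Among the compounds with values here, no pair of measured compounds covers a change of this kind, so the expectation for compound 3 rests on compound 2 alone. Since the change adds only a methyl group, a modest step in this assay is expected, toward a higher number, of about the size of the usual scatter or a little beyond it.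

Compound 3 is therefore expected to give about 0.02 nM in this assay, within a range from 0.003 nM to 0.2 nM. That estimate corresponds to an expected step of a 2.9-fold higher number from compound 2 to compound 3 (0.46 log units; beyond the scatter).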

Compound 3, half-maximal inhibitory concentration: 0.08 nM
Compound 3: the middle estimate sits 4.0-fold (0.60 log units) below what was measured, and the stated range covers the measured number.
By their numbers in this assay, from the lowest: compound 2; then compound 3; then compound 1.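

In this assay, methyl in place of hydrogen on this aromatic carbon, ortho to a large group, brings an 11-fold higher number from compound 2 to compound 3 (1.06 log units; beyond the scatter). Compound 1 and compound 2 differ in more than one place, so they could not show that a change of a single carbon at this place on the shared core is enough to weaken inhibition clearly. No measurement available here explains the size of this step.

On these data alone, it remains open whether a hydrogen at this place is specifically required, or whether another group, such as fluorine, chlorine, ethyl or methoxy, would bring a smaller or larger step. The compounds shown also leave open whether methyl on the other aromatic carbons of this ring would have a similar effect.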